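Methoxy in Place of Hydrogen on the Cinnamate Ring

A few compounds are considered here, and "the series" means these few. Any claim that something is new, unique, unknown or untested is made for them only; others in the source may bear on it.

Three compounds built on the shared core have been examined in a functional assay on EA.hy 926 cells (Homo sapiens) for cytotoxicity, read by MTT assay, with stated times of 24 h and 12 h, tested at 50 uM; a higher number here means a stronger effect of the compound at the concentration tested, a lower number a weaker effect. Compound 1 `Cc1nc(C)c(C(=O)Oc2ccc(/C=C/C(=O)O)cc2O)nc1C` gives 285%. Compound 2 `CCOC(=O)/C=C/c1ccccc1OC(=O)c1nc(C)c(C)nc1C` gives 36.9%, and compound 3 `Cc1nc(C)c(C(=O)Oc2ccccc2/C=C/C(=O)O)nc1C` gives 64.9%. Compound 3 thus holds the second highest of the three numbers: its nearest neighbour is compound 2, and compound 1 lies far above it. Among the compounds with values here, the one step between compounds differing in a single place is a number 28 percentage points higher from compound 2 to compound 3 (beyond the scatter), which came from hydrogen in place of ethyl on an oxygen next to a carbonyl group.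

Compound 4 `COc1ccc(/C=C/C(=O)O)c(OC(=O)c2nc(C)c(C)nc2C)c1` differs from compound 3 by methoxy in place of hydrogen on an aromatic carbon. Within the data shown here, no measured step concerns a methoxy group, so the step between compound 2 and compound 3 bears on the acid rather than on the ring substitution, and compound 1 differs from compound 3 in more than one place, so its number offers no clean comparison. Among the measured compounds shown here, with no relevant step to draw on, the expected change from compound 3 to compound 4 is estimated as none beyond the scatter, namely a number 5.1 percentage points higher from compound 3 to compound 4 (within the scatter). Compound 4 is therefore estimated to give 70% in this assay, in a range from 40% to 110%.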

Compound 4, a percentage reported as activity, at one concentration (the size of the read-out at that concentration, not a potency): 31.6%
Estimate against measurement, compound 4: 38.4 percentage points above; measured number outside the range, below it.
By their numbers in this assay, from the lowest: compounds 4 and 2 (each within the scatter of the next); then compound 3; then compound 1.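

In this assay, the change to methoxy on an aromatic carbon, meta to a large group and para to a 2-carboxyethenyl group, gives a number 33.3 percentage points lower from compound 3 to compound 4 (beyond the scatter) and so shows that this ring carbon does not tolerate every substitution without a change in the read-out. The earlier step, a number 28 percentage points higher from compound 2 to compound 3 (beyond the scatter), concerned the ethyl on the oxygen next to a carbonyl group and said nothing about the ring, whereas this one shows that adding a substituent of only 2 heavy atoms at this carbon is enough to move the number beyond the scatter, and downward. Nothing available explains why the number falls with this change.

Whether the fall belongs to methoxy itself or would follow any group at this carbon stays open, since the compounds shown say nothing about an amine, a chlorine atom or a longer ethoxy chain there. Also open, on these data alone, is whether methoxy at this carbon would have the same effect with an ethyl ester in place of the carboxylic acid.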